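A Third Aryl Group on a Shared Core

The source may report more compounds than this note shows. Statements on the series, on what has been measured and on what is new or still open speak of the compounds shown alone.

In a functional assay on PC-3 cells (Homo sapiens) for cytotoxicity, read by sulforhodamine B assay, with a stated time of 48 h (on this read-out higher numbers stand for weaker inhibition and lower numbers for stronger inhibition), compound 1 `C[C@H]1CC[C@@H]2[C@@H](OC(=O)[C@]23CC(c2ccc(N(C)C)cc2)=NO3)[C@]2(C)C(=O)C=C[C@@]12O` gives 6300 nM and compound 2 `Cc1ccccc1C1=NO[C@]2(C1)C(=O)O[C@@H]1[C@H]2CC[C@H](C)[C@]2(O)C=CC(=O)[C@@]12C` gives 10000 nM on the same core. Going by the values given here, these two numbers lie within the scatter of each other, so compound 2 stands level with the only other compound measured so far.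

Compound 3 `C[C@H]1CC[C@@H]2[C@@H](OC(=O)[C@]23CC(c2ccc(C#N)cc2)=NO3)[C@]2(C)C(=O)C=C[C@@]12O` has yet to be read. Its difference from compound 2 is 4-cyanophenyl in place of 2-methylphenyl on a carbon with a double bond to nitrogen with 4-cyanophenyl in place of 2-methylphenyl on a carbon with a double bond to nitrogen.

Among the compounds with values here, one measured step bears on this place. It is a 1.6-fold higher number from compound 1 to compound 2 (0.20 log units; within the scatter) for 2-methylphenyl in place of 4-(dimethylamino)phenyl on that same carbon, and it stays within the scatter. Within the data shown here, no measured compound carries 4-cyanophenyl, so the data offer no firm direction for the new group.

The expected change is a 1.3-fold lower number from compound 2 to compound 3 (0.10 log units; within the scatter) and nothing beyond the scatter is expected from it. For compound 3 the estimated value in this assay is 8000 nM with an expected range of 3000 nM to 20000 nM around it.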

Compound 3, half-maximal inhibitory concentration: 32000 nM
Estimate against measurement, compound 3: 4.0-fold (0.60 log units) below, and the stated range ends below it.
By their numbers in this assay, from the lowest: compounds 1 and 2 (each within the scatter of the next); then compound 3.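

Compound 3 shows that the aryl group on this carbon with a double bond to nitrogen can move the read-out in this assay beyond the scatter, which the step between compound 1 and compound 2 did not show. The change from 2-methylphenyl to 4-cyanophenyl gives a 3.2-fold higher number from compound 2 to compound 3 (0.51 log units; beyond the scatter) and the swap of dimethylamino for cyano on an aromatic carbon gives a 5.1-fold higher number from compound 1 to compound 3 (0.71 log units; beyond the scatter) so that, with both steps modest but beyond the scatter, compound 3 is the weakest of the three in this assay. No measurement shown here explains why the nitrile-bearing group gives the higher number.

As far as these compounds go, whether any group on this carbon can bring the number clearly below those of compound 1 and compound 2 remains open, since those two stand level and neither marks a gain over the other. From the compounds shown here alone, it is also open how far the result belongs to the nitrile itself, a question that a phenyl ring with no added group, or a methoxy group or a carboxylic acid in the nitrile's place, would help to settle.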